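The source may hold more compounds than are shown below. What is called first, only, known or untested is meant among the compounds shown, and "the series" means these compounds.

Measured compounds in a functional assay on HepG2 cells (Homo sapiens) for antiproliferative activity, read by MTT assay, with a stated time of 72 h; on this read-out higher numbers stand for weaker inhibition and lower numbers for stronger inhibition:

- Compound 1, `O=C1COc2ccc(-c3cccc(NS(=O)(=O)c4ccc(F)cc4)c3)cc2N1C1CC1`: in this assay compound 1 gives > 40000 nM, a limit of the assay rather than a number.
- Compound 2, `O=C1COc2ccc(-c3cnc(Cl)c(NS(=O)(=O)c4ccc(F)cc4)c3)cc2N1c1ccc(F)cc1`: in this assay compound 2 gives > 40000 nM, again a limit.
- Compound 3, `COc1ncc(-c2ccc3c(c2)N(c2ccc(F)cc2)C(=O)CO3)cc1NS(=O)(=O)c1ccc(F)cc1`: in this assay compound 3 gives 36400 nM.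

Compound 2 therefore stands at the limit, and the limit of > 40000 nM in this assay, at which 2 of the 3 values shown sit, shows it is not alone there. Going by the values given here, the only step between measured compounds is an at least 1.0-fold lower number from compound 2 to compound 3 (0.04 log units; that floor lies within the scatter), for methoxy in place of chloro on an aromatic carbon, a floor that lies within the scatter.

Compound 4, `Cc1ccc(N2C(=O)COc3ccc(-c4cnc(Cl)c(NS(=O)(=O)c5ccc(F)cc5)c4)cc32)cc1`, is not yet measured. It differs from compound 2 in this way: methyl in place of fluoro on an aromatic carbon. Among the compounds with values here, no measured step touches that ring, so nothing among the measured compounds speaks for a shift in either direction. Compound 4 is therefore expected to give about 40000 nM in this assay, within 20000 nM to 80000 nM. That estimate means an expected step of a number no higher from compound 2 to compound 4 (the limit leaves the size open), none beyond the scatter, with a limit the most likely outcome.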

Compound 4, half-maximal inhibitory concentration: 39600 nM
Estimate against measurement, compound 4: 1.0-fold (0.00 log units) above; low and high end bracket the measured number.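

In this assay compound 4 gives 39600 nM, so the 4-methylphenyl group, on a ring that the earlier step did not touch, brings no strong inhibition with it. Compound 2 gives > 40000 nM, a limit of the assay and not a number. The data therefore show only a number no higher from compound 2 to compound 4 (the limit leaves the size open) and the change of fluoro to methyl at this position stays without a measured effect, because compound 2 is not alone at that limit: the limit of > 40000 nM in this assay, at which 2 of the 4 values shown sit.

What the compounds shown leave open is how an amine, a carboxylic acid or a longer chain in place of the methyl would read on this ring. They also leave open whether the same change would read differently with methoxy in place of chloro.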